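A few compounds are considered here, and "the series" means these few. Any claim that something is new, unique, unknown or untested is made for them only; others in the source may bear on it.

In a functional assay on KB cells (Homo sapiens) for antiproliferative activity (on this read-out higher numbers stand for weaker inhibition and lower numbers for stronger inhibition), compound 1 (`COc1ccc(S(=O)(=O)N2CCc3cccc(Nc4ccc(O)cc4)c32)cc1`) gives 239 nM, while compound 2 (`COC(=O)c1ccc(Nc2cccc3c2N(S(=O)(=O)c2ccc(OC)cc2)CC3)cc1`) gives 93.5 nM, the lower of the two numbers. Compound 3 (`COc1ccc(S(=O)(=O)N2CCc3cccc(Nc4ccc(C(=O)O)cc4)c32)cc1`) differs from compound 2 by hydrogen in place of methyl on an oxygen next to a carbonyl group, with hydrogen in place of methyl on an oxygen next to a carbonyl group, turning methoxycarbonyl into carboxy. Among the compounds with values here, the only measured step that bears on this change is a 2.6-fold lower number from compound 1 to compound 2 (0.41 log units; beyond the scatter), which replaced hydroxy with methoxycarbonyl. Losing the methoxycarbonyl group here is therefore expected to reverse that direction, with a similarly modest size: a 3.2-fold higher number from compound 2 to compound 3 (0.51 log units; beyond the scatter). Compound 3 is estimated at 300 nM, within an expected range of 100 nM to 1200 nM.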

Compound 3, half-maximal inhibitory concentration: 846 nM
Compound 3: the middle estimate sits 2.8-fold (0.45 log units) below what was measured, and the stated range covers the measured number.
By their numbers in this assay, from the lowest: compound 2; then compound 1; then compound 3.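

Hydrogen in place of methyl on an oxygen next to a carbonyl group gives a 9.0-fold higher number from compound 2 to compound 3 (0.96 log units; beyond the scatter) and so shows that this small change weighs more than the swap of hydroxy for methoxycarbonyl did. Carboxy does not match hydroxy on this aromatic carbon either, with a 3.5-fold higher number from compound 1 to compound 3 (0.55 log units; beyond the scatter) separating them, so the number at this place rises from methoxycarbonyl through hydroxy to carboxy. On these data alone, whether a primary amide or an ethyl ester here would stay nearer compound 2 or compound 3 remains open. Nothing measured alongside these numbers accounts for the gaps.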